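The source may report more compounds than this note shows. Statements on the series, on what has been measured and on what is new or still open speak of the compounds shown alone.

Compound 1, `CN(C)CCCCCSC1=Nc2ccccc2C(CC(=O)NCc2ccccc2)N1c1ccc(-c2ccccc2)cc1`, gives 18100 nM in a functional assay on A549 cells (Homo sapiens) for cytotoxicity, read by MTT assay, with a stated time of 48 h; a higher number here means a weaker inhibitor, a lower number a stronger inhibitor. Compound 2, `CN(C)CCCCCSC1=Nc2ccccc2C(CC(=O)NCc2ccc(F)cc2)N1c1ccc(-c2ccccc2)cc1`, gives 5000 nM. Compound 3, `CN(C)CCCCCSC1=Nc2ccccc2C(CC(=O)NCc2ccc(F)cc2)N1c1ccccc1`, gives 36800 nM.

Compound 4, `CN(C)CCCCCSC1=Nc2ccccc2C(CC(=O)NCc2ccccc2)N1c1ccccc1`, has not been measured. Its core is that of compound 3, which differs from the core of compound 2 by hydrogen in place of phenyl on an aromatic carbon; that step gave a 7.4-fold higher number from compound 2 to compound 3 (0.87 log units; beyond the scatter). The change from compound 3 to compound 4 is hydrogen in place of fluoro on an aromatic carbon. The same change, (hydrogen in place of fluoro on an aromatic carbon), has already been made once, from compound 2 to compound 1, where it gave a 3.6-fold higher number from compound 2 to compound 1 (0.56 log units; beyond the scatter). Going by the values given here, because that step a 3.6-fold higher number from compound 2 to compound 1 (0.56 log units; beyond the scatter) weakened inhibition on the other core, compound 4 is expected to be weaker than compound 3 by about as much, that is a 3.0-fold higher number from compound 3 to compound 4 (0.48 log units; beyond the scatter), with the pattern resting on only one earlier pair. Compound 4 is therefore estimated at 110000 nM, with a likely range from 40000 nM to 300000 nM.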

Compound 4, half-maximal inhibitory concentration: 138000 nM
Estimate against measurement, compound 4: 1.3-fold (0.10 log units) below; low and high end bracket the measured number.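

In this assay, hydrogen in place of fluoro gives a 3.8-fold higher number from compound 3 to compound 4 (0.57 log units; beyond the scatter), and this step carries over closely from the core bearing the extra phenyl: the same change on two cores in this assay, a 3.6-fold higher number (0.56 log units; beyond the scatter) from compound 2 to compound 1 and a 3.8-fold higher number (0.57 log units; beyond the scatter) from compound 3 to compound 4, 1.0-fold (0.02 log units) apart, within the scatter of two such steps. Hydrogen in place of phenyl gives a 7.6-fold higher number from compound 1 to compound 4 (0.88 log units; beyond the scatter), and this step also repeats on the second core: the same change on two cores in this assay, a 7.4-fold higher number (0.87 log units; beyond the scatter) from compound 2 to compound 3 and a 7.6-fold higher number (0.88 log units; beyond the scatter) from compound 1 to compound 4, 1.0-fold (0.02 log units) apart, within the scatter of two such steps. Within these four compounds, each change therefore has about the same size whichever form the other site takes, but this rests on a single set of compounds in one cell assay and does not show why either change matters or whether the match extends to other cores.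

From the compounds shown here alone, it remains open whether chloro or methoxy in place of the fluoro would give a similar step. Also open, going by these compounds, is whether both steps would hold with a shorter or longer chain ending in the dimethylamine.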